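The source may report more compounds than this note shows. Statements on the series, on what has been measured and on what is new or still open speak of the compounds shown alone.

Compounds measured so far:
Compound 1 `Cc1ccc(S(=O)(=O)N2C=CNC(=O)[C@H]2CC(=O)N[C@@H]2CCCc3cc(CN(C)C)ccc32)cc1`: 0.21 nM
Compound 2 `Cc1ccc(S(=O)(=O)N2C=CNC(=O)[C@H]2CC(=O)N[C@@H]2CCCc3ccccc32)cc1`: 3.3 nM
Compound 3 `Cc1ccc(S(=O)(=O)N2C=CNC(=O)[C@H]2CC(=O)N[C@@H]2CC(=O)Nc3ccccc32)cc1`: 96 nM

Within the data shown here, in an in vitro functional assay on cells for antagonist activity at B1 bradykinin receptor (Homo sapiens), read by luminescence and calcium flux, with a stated time of 2 h (on this read-out lower numbers stand for stronger inhibition and higher numbers for weaker inhibition), compound 2 stands second of the three numbers: compound 1 gives the lowest number, and the step of a 16-fold higher number from compound 1 to compound 2 (1.20 log units; beyond the scatter) is the one measured change, hydrogen in place of (dimethylamino)methyl on an aromatic carbon. Among the measured compounds shown here, compound 3 gives the highest number of the three, and no single-place step links it to compound 2.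

Compound 4 `Cc1ccc(S(=O)(=O)N2C=CNC(=O)[C@H]2CC(=O)NC2CCC(C)CC2)cc1` differs from compound 2 by 4-methylcyclohexyl in place of 1,2,3,4-tetrahydronaphthalen-1-yl on an amide-type nitrogen. For the measured compounds named here, none of the measured steps touches the group on this amide-type nitrogen, so no measured step bears on it directly; the values of compound 2 and compound 3 only show that a change at this position can move the number a long way. A change that removes the aromatic ring of the 1,2,3,4-tetrahydronaphthalen-1-yl group is therefore expected to give a higher number, of a size a 9.1-fold higher number from compound 2 to compound 4 (0.96 log units; beyond the scatter), with wide uncertainty. Compound 4 is estimated at 30 nM, within 5 nM to 300 nM.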

Compound 4, half-maximal inhibitory concentration: 314 nM
The estimate for compound 4 lay 10-fold (1.02 log units) below the measured number; measured number outside the range, above it.
By their numbers in this assay, from the lowest: compound 1; then compound 2; then compound 3; then compound 4.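

In this assay, among these compounds, the step of a 95-fold higher number from compound 2 to compound 4 (1.98 log units; beyond the scatter) is the first measured change to the group on the amide-type nitrogen, and it shows that this group has a very large bearing on the number. Replacing 1,2,3,4-tetrahydronaphthalen-1-yl with 4-methylcyclohexyl leaves a single non-aromatic ring of carbon on that nitrogen and costs more than the change on the aromatic carbon, a 16-fold higher number from compound 1 to compound 2 (1.20 log units; beyond the scatter) in the same assay. Nothing available here accounts for the size of this step.

The compounds shown do not separate the loss of the aromatic ring from the other differences between the two groups, including the methyl on the cyclohexyl ring. From the compounds shown here alone, a plain cyclohexyl or a benzyl on the amide-type nitrogen would bear on this, and it remains open whether a (dimethylamino)methyl group would lower the number of compound 4 as it does that of compound 2.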